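The source may hold more compounds than are shown below. What is called first, only, known or untested is meant among the compounds shown, and "the series" means these compounds.

Compound 1 `COc1ccc(C2N=C(SCc3ccccc3Cl)NC(C)=C2C(=O)Nc2ccc(F)cc2)cc1OC`: 39.2%
Compound 2 `CC1=C(C(=O)Nc2ccc(F)cc2)C(c2ccc([N+](=O)[O-])cc2)N=C(SCc2ccccc2Cl)N1`: 21.6%

In a functional assay on the whole organism (artery, strain albino) with Rattus norvegicus as the target, with a stated time of 360 min, at a dose of 10 mg/kg by the oral route (a higher number here means more inhibition at the dose given (going by the name of the read-out), a lower number less inhibition), compound 2 gives 21.6%, the lower of the two numbers; the step of a number 17.6 percentage points lower from compound 1 to compound 2 (beyond the scatter) separates it from compound 1. Compound 3 `CC1=C(C(=O)Nc2ccc(F)cc2)C(c2ccc([N+](=O)[O-])cc2)N=C(SCc2ccc(F)cc2)N1` differs from compound 2 by 4-fluorophenyl in place of 2-chlorophenyl on a saturated chain carbon bound to a sulfur. Among the compounds with values here, no measured pair varies the group on the saturated chain carbon bound to a sulfur, so the measured step from compound 1 to compound 2 does not bear on this change. The step of a number 0.4 percentage points higher from compound 2 to compound 3 (within the scatter) is therefore expected to stay within the scatter. Compound 3 is estimated at 22%, in the range 6% to 38%.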

Compound 3, a percentage reported as inhibition, in the whole organism at one dose (the size of the read-out at that dose, not a potency): 33%
The estimate for compound 3 lay 11 percentage points below the measured number; measured number inside the range.
By their numbers in this assay, from the lowest: compound 2; then compounds 3 and 1 (each within the scatter of the next).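

In this assay, 4-fluorophenyl in place of 2-chlorophenyl on a saturated chain carbon bound to a sulfur gives a number 11.4 percentage points higher from compound 2 to compound 3 (beyond the scatter) and shows that this place also affects the read-out, which the earlier pair, varied only on a saturated ring carbon, could not show. Nothing at hand explains this step.

The single step alters both the halogen and where it stands on the phenyl ring, so the compounds shown do not separate the two. Going by these compounds, it also remains open how an unsubstituted phenyl or a longer alkyl chain would read in this place.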